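Sulfonate ester variation on a P2X7 antagonist scaffold

The compounds below may be only part of what the source reports. "The series", "measured", "known", "first", "only" and "open" are said of these compounds alone.

Measured so far:
- compound 1 `CS(=O)(=O)Oc1ccc(-c2cncn2C2CCN(C(=O)c3ccc(Cl)c(C(F)(F)F)c3)CC2)cc1`: 1570 nM
- compound 2 `O=C(NC1CC1)c1cccc(S(=O)(=O)Oc2ccc(-c3cncn3C3CCN(C(=O)c4ccc(Cl)c(C(F)(F)F)c4)CC3)cc2)c1`: 88 nM

In an assay on HEK293 cells for antagonist activity at P2X purinoceptor 7 (Homo sapiens), read by fluorescence, with a stated time of 2 h (a lower number here means a stronger inhibitor, a higher number a weaker inhibitor), compound 2 gives the lowest number of the two; the nearest, compound 1, stands well above it. Going by the values given here, the one measured step, an 18-fold lower number from compound 1 to compound 2 (1.25 log units; beyond the scatter), shows that an aromatic group on the sulfonyl sulfur in place of a methyl helps strongly. Compound 3 `O=C(c1ccc(Cl)c(C(F)(F)F)c1)N1CCC(n2cncc2-c2ccc(OS(=O)(=O)c3cccc4cnccc34)cc2)CC1` carries the change (isoquinolin-5-yl in place of 3-(cyclopropylcarbamoyl)phenyl on a sulfonyl sulfur). It keeps an aromatic group there but loses the hydrogen-bond donor, so the step of a 1.7-fold higher number from compound 2 to compound 3 (0.23 log units; within the scatter) is expected to be small. Compound 3 is estimated at 150 nM, within 40 nM to 600 nM.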

Compound 3, half-maximal inhibitory concentration: 45 nM
Estimate against measurement, compound 3: 3.3-fold (0.52 log units) above; the range from low to high includes it.
By their numbers in this assay, from the lowest: compounds 3 and 2 (each within the scatter of the next); then compound 1.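

In this assay the change to isoquinolin-5-yl gives a 2.0-fold lower number from compound 2 to compound 3 (0.29 log units; within the scatter) and so, in this pair, the hydrogen-bond donor of 3-(cyclopropylcarbamoyl)phenyl is not required for activity on the sulfonyl sulfur. The gain over methyl also holds for a second aromatic group, with a 35-fold lower number from compound 1 to compound 3 (1.54 log units; beyond the scatter) for this replacement. No evidence here explains either step.

Still open, as far as these compounds go, is how a plain phenyl or a pyridine ring would compare on the sulfonyl sulfur. Also open, from the compounds shown here alone, is whether an amine or a carboxylic acid on the aromatic ring would be tolerated.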